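Fluorinated Anilide on a Pyridylmethyl Core: Expected Cytotoxicity

A few compounds are considered here, and "the series" means these few. Any claim that something is new, unique, unknown or untested is made for them only; others in the source may bear on it.

Of the compounds shown here, three built on a shared core have been measured in a functional assay on HT-29 cells (Homo sapiens) for cytotoxicity, read by MTT assay, with a stated time of 72 h; a higher number here means a weaker inhibitor, a lower number a stronger inhibitor. Compound 2 `Cc1ccccc1NC(=O)CN1CCN(c2nnc(Cc3ccccc3)c3ccccc23)CC1` gives 113000 nM in this assay. Compound 1 `O=C(CN1CCN(c2nnc(Cc3ccccc3)c3ccccc23)CC1)Nc1ccc(F)c(F)c1` differs from compound 2 only at the anilide end, (3,4-difluorophenyl in place of 2-methylphenyl on an amide-type nitrogen), and in this assay compound 1 gives 9510 nM; the step is a 12-fold lower number from compound 2 to compound 1 (1.07 log units; beyond the scatter). Compound 3 `Cc1ccccc1NC(=O)CN1CCN(c2nnc(Cc3ccncc3)c3ccccc23)CC1` keeps the anilide of compound 2 but differs in the core, (pyridin-4-yl in place of phenyl on a saturated chain carbon bound to an aromatic carbon). In this assay compound 3 gives 15000 nM, and the step is a 7.5-fold lower number from compound 2 to compound 3 (0.88 log units; beyond the scatter). The values of compound 3 and compound 1 lie within the scatter of each other, so no order between them is claimed.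

Compound 4 `O=C(CN1CCN(c2nnc(Cc3ccncc3)c3ccccc23)CC1)Nc1ccc(F)c(F)c1` has not yet been measured. It stands to compound 3 as compound 1 stands to compound 2: 3,4-difluorophenyl in place of 2-methylphenyl on an amide-type nitrogen. The place is the same in both pairs, an amide-type nitrogen whose other neighbour is a carbonyl carbon, so this is the same change, now made on the core of compound 3 instead of that of compound 2. Going by the values given here, the only evidence for what it does is the single step of a 12-fold lower number from compound 2 to compound 1 (1.07 log units; beyond the scatter), seen on a different core; no other pair shows whether it carries over. Compound 4 is therefore expected to show a step of an 8.3-fold lower number from compound 3 to compound 4 (0.92 log units; beyond the scatter) in this assay, kept a little smaller than that earlier step since it rests on one example alone. The value expected for compound 4 in this assay is 1800 nM, with a range from 600 nM to 6000 nM.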

Compound 4, half-maximal inhibitory concentration: 2320 nM
Compound 4: the middle estimate sits 1.3-fold (0.11 log units) below what was measured, within the range that was stated.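

In this assay, 3,4-difluorophenyl in place of 2-methylphenyl on the amide-type nitrogen gives a 6.5-fold lower number from compound 3 to compound 4 (0.81 log units; beyond the scatter), while pyridin-4-yl in place of phenyl on the saturated chain carbon gives a 4.1-fold lower number from compound 1 to compound 4 (0.61 log units; beyond the scatter). The 3,4-difluorophenyl change thus keeps its direction on the second core, and its size there cannot be told apart from its size on the first: the same change on two cores in this assay, a 12-fold lower number (1.07 log units; beyond the scatter) from compound 2 to compound 1 and a 6.5-fold lower number (0.81 log units; beyond the scatter) from compound 3 to compound 4, 1.8-fold (0.26 log units) apart, within the scatter of two such steps. Going by these compounds alone, the pyridin-4-yl change behaves in the same way, but these four compounds show only that each change carries over between these two cores and in this one cell assay, not that either would do so on any other core: the same change on two cores in this assay, a 7.5-fold lower number (0.88 log units; beyond the scatter) from compound 2 to compound 3 and a 4.1-fold lower number (0.61 log units; beyond the scatter) from compound 1 to compound 4, 1.8-fold (0.26 log units) apart, within the scatter of two such steps.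

The compounds shown leave open whether both fluorines are needed on the anilide, since neither a plain phenyl, a monofluorophenyl nor a chlorophenyl group on the amide-type nitrogen appears among them. They also leave open whether a pyrimidine ring or a plain alkyl group could stand in place of pyridin-4-yl on the saturated chain carbon, and whether the same steps would appear on cell lines other than this one.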